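Replacing the Nitrophenyl Arm Before Cytotoxicity Is Measured

The source may hold more compounds than are shown below. What is called first, only, known or untested is meant among the compounds shown, and "the series" means these compounds.

In a toxicity assay on cells (Macrophage, Mus musculus, strain BALB/c) for cytotoxicity, read by MTT assay (on this read-out lower numbers stand for stronger inhibition and higher numbers for weaker inhibition), three compounds have been measured. Compound 1 `C=CCOc1cc(OC)c(C(=O)/C=C/c2ccc([N+](=O)[O-])cc2)c(OCC=C)c1` gives 13200 nM. Compound 2 `C=CCOc1cc(OC)c(C(=O)/C=C/c2cc(OC)c(OC)c(OC)c2)c(OCC=C)c1` shares the core of compound 1, and compound 2 gives 12000 nM. Compound 3 `COc1cccc(/C=C/C(=O)c2c(O)cc(O)cc2OC)c1`, built on a different core, gives 17600 nM. The number for compound 1 falls between those of compound 2 and compound 3, and both gaps lie within the usual scatter of repeated measurements, so the three compounds cannot be told apart on this read-out.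

Compound 4 `C=CCOc1cc(OC)c(C(=O)/C=C/c2cccc(OC)c2)c(OCC=C)c1` has not yet been measured in this assay. It keeps the core of compound 1 and differs in one place: 3-methoxyphenyl in place of 4-nitrophenyl on a double-bonded chain carbon bound to a double-bonded chain carbon. Going by the values given here, no measured pair in this set differs by exactly this change, so there is no step to lean on. What can be said is that compound 3 also carries a 3-methoxyphenyl and its value of 17600 nM sits close to compound 1, and that compound 2, carrying a different group there, gives 12000 nM. All three numbers cluster together. The step is therefore estimated as a 1.1-fold higher number from compound 1 to compound 4 (0.03 log units; within the scatter), within the scatter rather than beyond it. Compound 4 is expected to give about 14000 nM, with a range of 7000 nM to 28000 nM.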

Compound 4, half-maximal inhibitory concentration: 13100 nM
Estimate against measurement, compound 4: 1.1-fold (0.03 log units) above, and the stated range covers the measured number.
By their numbers in this assay, from the lowest: compounds 2, 4, 1 and 3 (each within the scatter of the next).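

Going by these compounds alone, exchanging 4-nitrophenyl for 3-methoxyphenyl on a double-bonded chain carbon bound to a double-bonded chain carbon gives, in this assay, a 1.0-fold lower number from compound 1 to compound 4 (0.00 log units; within the scatter) and so provides the first direct reading of this position, which no earlier pair could give, as no two of the earlier compounds differed in only one place. The change is not a small one on paper: a ring bearing a nitro group gives way to a ring bearing a methoxy group, with a nitrogen gone and a hydrogen-bond acceptor fewer, yet the number in this assay stays within the scatter, so for this one pair the exchange leaves the cytotoxicity reading in macrophages effectively unchanged. Nothing available here gives a reason for this flat result.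

This single step changes both the group and its printed location on the ring, so the contribution of each cannot be separated, and a 4-methoxyphenyl would be needed to pull the two apart. Going by these compounds, whether an aminophenyl, or a phenyl ring carrying a carboxylic acid, would also stay within the scatter at this position remains open.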